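Swapping neopentyl for anilino in a solubility series

This account rests on a few compounds, and the source may have more. Where it says the series, first, only, none or still open, it means among the compounds named here.

In a physicochemical assay for solubility (a higher number here means a more soluble compound, a lower number a less soluble compound), compound 1 `O=C(Cn1ccnc1)N1CCC(NS(=O)(=O)c2cc(S(=O)(=O)c3ccccc3)ccc2C(F)(F)F)CC1` gives 100000 nM. Within the data shown here, compound 2 `CC(C)(C)CC(=O)N1CCC[C@H]1C(=O)N1CCC(NS(=O)(=O)c2cc(S(=O)(=O)c3ccccc3)ccc2C(F)(F)F)CC1` gives 25000 nM, the lower of the only two numbers available so far. The next compound to be measured is compound 3 `O=C([C@@H]1CCCN1C(=O)Nc1ccccc1)N1CCC(NS(=O)(=O)c2cc(S(=O)(=O)c3ccccc3)ccc2C(F)(F)F)CC1`, which keeps most of compound 2 unchanged. The difference is anilino in place of neopentyl on a carbonyl carbon. The same difference can be read as neopentylcarbonyl to phenylcarbamoyl.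

Among the measured compounds shown here, only one measured step bears on this change, and only indirectly. a 4.0-fold lower number from compound 1 to compound 2 (0.60 log units; beyond the scatter) was a modest step, and it replaced the whole group on the carbonyl carbon, whereas the new change alters only a part of that group. For the measured compounds named here, no measured compound here carries an anilino group, so the direction is a weak call. A step no larger than the measured one seems likely, leaning slightly lower and possibly within the scatter. The expected change is an estimated 1.6-fold lower number from compound 2 to compound 3 (0.19 log units; within the scatter). For compound 3, the estimated value in this assay is 16000 nM, with an expected range from 6000 nM to 40000 nM.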

Compound 3, solubility: 25000 nM
Compound 3: middle estimate off by 1.6-fold (0.19 log units), on the low side; low and high end bracket the measured number.
By their numbers in this assay, from the lowest: compounds 2 and 3 (each within the scatter of the next); then compound 1.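

In this assay the exchange of neopentyl for anilino on a carbonyl carbon gives no change at the digits printed from compound 2 to compound 3 (within the scatter) and so adds a new kind of end group to the series: an aromatic ring and a hydrogen-bond donor enter in place of an open carbon group, and the two numbers cannot be told apart. Among these compounds, the only earlier step, a 4.0-fold lower number from compound 1 to compound 2 (0.60 log units; beyond the scatter), replaced the whole group on a carbonyl carbon, so it could not show what a change confined to the far end of that group would do; this pair shows one such change that leaves the read-out where it was. No measurement available here explains why the number stays put.

This is a single pair, so it gives no rule for the position, and two end groups say little about the range of groups it would accept. A basic amine such as a dimethylamino group, a carboxylic acid, or a longer carbon chain on the same carbonyl carbon could still show whether the read-out at this place can move at all.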